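Bromine on the phenyl ring: an estimate for compound 4

A few compounds are considered here, and "the series" means these few. Any claim that something is new, unique, unknown or untested is made for them only; others in the source may bear on it.

Measured compounds:
Compound 1, `CN(C)/C=N/c1c(C=O)c(-c2ccccc2)nn1-c1ccccc1`, gives 9300 nM.
Compound 2, `Cc1cccc(-n2nc(-c3ccccc3)c(C=O)c2/N=C/N(C)C)c1`, gives 8900 nM.
Compound 3, `CN(C)/C=N/c1c(C=O)c(-c2ccccc2)nn1-c1cccc([N+](=O)[O-])c1`, gives 36700 nM.

All three were tested in a functional assay on NPC-TW01 cells (Homo sapiens) for inhibition, read by MTT assay, with a stated time of 72 h; a lower number here means a stronger inhibitor of growth, a higher number a weaker inhibitor of growth. Compound 1 stands second highest of the three numbers shown; its nearest neighbour is compound 2, as the step of a 1.0-fold lower number from compound 1 to compound 2 (0.02 log units; within the scatter) shows, and the furthest is compound 3, as the step of a 3.9-fold higher number from compound 1 to compound 3 (0.60 log units; beyond the scatter) shows. The step of a 4.1-fold higher number from compound 2 to compound 3 (0.62 log units; beyond the scatter) points the same way.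

The unmeasured compound 4, `CN(C)/C=N/c1c(C=O)c(-c2ccccc2)nn1-c1ccc(Br)cc1`, differs from compound 1 in one place: bromo in place of hydrogen on an aromatic carbon.

Among the measured compounds shown here, two measured steps bear on this change, since both alter a hydrogen on the same phenyl ring of the shared core. Putting a methyl there left the number unchanged within the scatter, while putting a nitro there gave a modestly higher number. For the measured compounds named here, a bromo is neither of these groups, and no step with a halogen is available. The expected outcome for compound 4 is therefore a step of about a 1.2-fold higher number from compound 1 to compound 4 (0.07 log units; within the scatter), that is, little or no change beyond the scatter, with the range leaning toward a somewhat higher number. Compound 4 is estimated at 11000 nM, between 4000 nM and 32000 nM.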

Compound 4, concentration for 50% growth inhibition: 7400 nM
Compound 4: middle estimate off by 1.5-fold (0.17 log units), on the high side; low and high end bracket the measured number.
By their numbers in this assay, from the lowest: compounds 4, 2 and 1 (each within the scatter of the next); then compound 3.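

In this assay, a halogen on this phenyl ring, here a bromo para to a large group, gives a number that cannot be told apart from that of the unsubstituted ring (a 1.3-fold lower number from compound 1 to compound 4 (0.10 log units; within the scatter)). The 4-bromophenyl and 3-methylphenyl compounds also cannot be told apart (a 1.2-fold lower number from compound 2 to compound 4 (0.08 log units; within the scatter)), so compound 1, compound 2 and compound 4 sit together, and a hydrogen on this ring can give way to either a bromo or a methyl with no step beyond the scatter. Compound 3 alone stands apart from this group (a 5.0-fold lower number from compound 3 to compound 4 (0.70 log units; beyond the scatter)), although that last step swaps both the group and its place on the ring, so it cannot say which of the two matters.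

The compounds shown leave open whether a bromo placed where the methyl and nitro sit would behave as it does here, and whether an amine or a carboxylic acid on this ring would stay with compound 1 or move towards compound 3. No measurement shown here gives any reason for these numbers.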